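A few compounds are considered here, and "the series" means these few. Any claim that something is new, unique, unknown or untested is made for them only; others in the source may bear on it.

Measured so far, in a functional assay on CHO-K1 cells for antagonist activity at adenosine receptor A1 (Homo sapiens), read by a beta-galactosidase reporter and cAMP accumulation, with stated times of 15 min and 6 h; a lower number here means a stronger inhibitor, a higher number a weaker inhibitor:
- compound 1 `Nc1nc(-c2ccc(C3CC3)o2)nc2sc(Cc3ccccc3)cc12` gives 861 nM
- compound 2 `COc1ccccc1Cc1cc2c(N)nc(-c3nc(C)cs3)nc2s1` gives 186 nM
- compound 3 `C=C(c1ccccc1)c1cc2c(N)nc(-c3nc(C)cs3)nc2s1` is reported only as a limit, > 594 nM, which is the limit of > 594 nM in this assay, at which 1 of the 3 values shown sits.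

Compound 1 therefore holds the higher of the two real numbers in this assay, and the gap down to compound 2 lies beyond the usual scatter. The step examined here leads from compound 1 to compound 4 `Nc1nc(-c2ncccn2)nc2sc(Cc3ccccc3)cc12`, where the change is pyrimidin-2-yl in place of 5-cyclopropylfuran-2-yl on an aromatic carbon. Among the compounds with values here, no measured pair shows this kind of exchange, so the expectation rests on compound 1 alone. A modest rise in the number is expected, as given by a 1.7-fold higher number from compound 1 to compound 4 (0.24 log units; within the scatter). Compound 4 is accordingly estimated at 1500 nM, within 400 nM to 6000 nM.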

Compound 4, inhibition constant: 618 nM
Compound 4: middle estimate off by 2.4-fold (0.39 log units), on the high side; the measured number falls inside the stated range.
By their numbers in this assay, from the lowest: compound 2; then compounds 4 and 1 (each within the scatter of the next).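

At the aromatic carbon between two ring nitrogen atoms, placing pyrimidin-2-yl in place of 5-cyclopropylfuran-2-yl gives, in this assay, a 1.4-fold lower number from compound 1 to compound 4 (0.14 log units; within the scatter). Within the data shown here, this is the first exchange at this place, and it shows that two quite different aromatic groups, one carrying a three-membered ring and the other without one, give values within the scatter of each other. No measurement shown gives a cause for this step. The compounds shown leave open how a non-aromatic group, such as an amine or a carboxylic acid, would read at this place.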